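From Bromo to Methoxy in a Barely Active Compound

This account rests on a few compounds, and the source may have more. Where it says the series, first, only, none or still open, it means among the compounds named here.

In a functional assay on DU-145 cells (Homo sapiens) for inhibition, read by trypan blue exclusion, with a stated time of 96 h (on this read-out lower numbers stand for stronger inhibition of growth and higher numbers for weaker inhibition of growth), compound 1 (`COc1ccc(C(=O)/C(=C\c2ccc(Br)cc2)Sc2ccc(F)cc2)cc1`) gives > 100000 nM, which is a limit of the assay and not a number. Compound 2 (`O=C(/C(=C\c1ccc(O)cc1)SCc1ccc(F)cc1)c1ccc(Br)cc1`) differs from it in more than one place and gives 10000 nM in this assay. Compound 3 (`COc1ccc(/C=C(/Sc2ccc(F)cc2)C(=O)c2ccc(OC)cc2)cc1`) keeps the core of compound 1 but changes one substituent, with methoxy in place of bromo on an aromatic carbon, para to a large group, turning 4-bromophenyl into 4-methoxyphenyl (methoxy in place of bromo on an aromatic carbon). For the measured compounds named here, no measured pair shows what this exchange does on its own, so only a small shift toward stronger inhibition of growth is expected, and another reading at the limit would be no surprise. The expected step is an at least 1.2-fold lower number from compound 1 to compound 3 (0.09 log units; that floor lies within the scatter). For compound 3, the estimated value in this assay is 80000 nM, with an expected range from 20000 nM to 200000 nM.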

Compound 3, concentration for 50% growth inhibition: 25000 nM
For compound 3 the middle estimate is 3.2-fold (0.51 log units) above the measured one, and the stated range covers the measured number.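

Replacing bromo with methoxy on this aromatic carbon, para to a large group, moves the compound from a limit to a real reading in this assay, giving an at least 4.0-fold lower number from compound 1 to compound 3 (0.60 log units; beyond the scatter). For the compounds shown here, this is the first view of this exchange on its own, and it shows that this position can change the read-out by more than the usual scatter. The true size of the step remains unknown, because the value for compound 1 is a limit of the assay and not a number: the limit of > 100000 nM in this assay, at which 1 of the 3 values shown sits.

Going by these compounds alone, compound 2 differs from the other two compounds in more than one place, so no step involving it can be read. On these data alone, how an amine or an ethoxy group would behave at this position remains open.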